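Methylsulfonyl Aryl in Place of Trifluoromethyl Aryl

A few compounds are considered here, and "the series" means these few. Any claim that something is new, unique, unknown or untested is made for them only; others in the source may bear on it.

Compound 1 `CCCS(=O)(=O)Nc1ccc(F)c(C(=O)c2n[nH]c3ncc(-c4cccc(OC)c4)cc23)c1F` gives 6.3% in an assay for binding affinity to dual specificity mitogen-activated protein kinase kinase 4 (Homo sapiens), read by KINOMEscan, tested at 100 nM; on this read-out higher numbers stand for a weaker effect at the one concentration tested and lower numbers for a stronger effect.
Compound 2 `CCCS(=O)(=O)Nc1ccc(F)c(C(=O)c2n[nH]c3ncc(-c4cccc(N(C)C)c4)cc23)c1F` gives 26% in this assay.
Compound 3 `CCCS(=O)(=O)Nc1ccc(F)c(C(=O)c2n[nH]c3ncc(-c4cccc(C(F)(F)F)c4)cc23)c1F` gives 57% in this assay.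

Compound 3 stands highest of the three numbers, beyond the scatter from both others: a number 50.7 percentage points higher from compound 1 to compound 3 (beyond the scatter) and a number 31 percentage points higher from compound 2 to compound 3 (beyond the scatter). Compound 4 `CCCS(=O)(=O)Nc1ccc(F)c(C(=O)c2n[nH]c3ncc(-c4ccc(S(C)(=O)=O)cc4)cc23)c1F` differs from compound 3 by 4-(methylsulfonyl)phenyl in place of 3-(trifluoromethyl)phenyl on an aromatic carbon. The two measured steps that end at compound 3 both bear on this change, since each exchanged the group on the same aromatic carbon, and both were large. Within the data shown here, no measured step involves a methylsulfonyl group, so the size is uncertain. A step of a number 27 percentage points lower from compound 3 to compound 4 (beyond the scatter) is expected in this assay, that is a lower number. Compound 4 is estimated at 30%, within 5% to 70%.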

Compound 4, a percentage reported as activity, at one concentration (the size of the read-out at that concentration, not a potency): 1.5%
Estimate against measurement, compound 4: 28.5 percentage points above; measured number below the stated range.
By their numbers in this assay, from the lowest: compounds 4 and 1 (each within the scatter of the next); then compound 2; then compound 3.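

In this assay, 4-(methylsulfonyl)phenyl on this aromatic carbon gives a number 55.5 percentage points lower from compound 3 to compound 4 (beyond the scatter) and a number 24.5 percentage points lower from compound 2 to compound 4 (beyond the scatter), showing that a substituted phenyl here need not be a 3-substituted one to give a low number. Against 3-methoxyphenyl it gives a number 4.8 percentage points lower from compound 1 to compound 4 (within the scatter), placing compound 4 with compound 1 at the low end of this series. No supporting evidence accounts for these steps.

This change alters both the group and where it sits on the phenyl ring, so the compounds leave open which of the two matters. Going by these compounds, how 3-(methylsulfonyl)phenyl or a phenyl bearing a carboxylic acid would read also remains open.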